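A few compounds are considered here, and "the series" means these few. Any claim that something is new, unique, unknown or untested is made for them only; others in the source may bear on it.

Of the compounds shown here, three have so far been measured in a functional assay on HL-60 cells (Homo sapiens) for cytotoxicity, read by MTT assay, with a stated time of 48 h; a lower number here means a stronger inhibitor, a higher number a weaker inhibitor. Compound 1 `O=c1ccc2cc(OCc3cn(-c4ccccc4)nn3)ccc2o1` gives 41600 nM. Compound 2 `CC(=O)Nc1ccc(-n2cc(COc3ccc4oc(=O)ccc4c3)nn2)cc1`, which bears an acetamido in place of hydrogen on an aromatic carbon, gives 40400 nM; the step of a 1.0-fold lower number from compound 1 to compound 2 (0.01 log units; within the scatter) lies within the scatter. Compound 3 `O=c1ccc2cc(OCc3cn(-c4cccc([N+](=O)[O-])c4)nn3)ccc2o1`, with a nitro in place of hydrogen on an aromatic carbon, gives 20500 nM; the step of a 2.0-fold lower number from compound 1 to compound 3 (0.31 log units; beyond the scatter) is modest but beyond the scatter. Compound 3 thus holds the lowest of the three numbers, although its gap to compound 2 is within the scatter, and only its gap to compound 1 is beyond it.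

Compound 4 `O=c1ccc2cc(OCc3cn(-c4ccc([N+](=O)[O-])cc4)nn3)ccc2o1` has not yet been measured. It differs from compound 3 by 4-nitrophenyl in place of 3-nitrophenyl on an aromatic nitrogen; the two have the same atoms, joined differently. Within the data shown here, none of the measured steps moves a group from one position to another: the step of a 1.0-fold lower number from compound 1 to compound 2 (0.01 log units; within the scatter) adds an acetamido and stays within the scatter, and the step of a 2.0-fold lower number from compound 1 to compound 3 (0.31 log units; beyond the scatter) adds a nitro and is only modest. Since compound 4 keeps the nitro, the move from 3-nitrophenyl to 4-nitrophenyl is expected to give no step beyond the scatter in this assay. Compound 4 is therefore estimated at 20000 nM in this assay, with a range from 8000 nM to 50000 nM. The expected step is a 1.0-fold lower number from compound 3 to compound 4 (0.01 log units; within the scatter), none beyond the scatter.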

Compound 4, half-maximal inhibitory concentration: 46000 nM
Compound 4: the middle estimate sits 2.3-fold (0.36 log units) below what was measured, and the stated range covers the measured number.
By their numbers in this assay, from the lowest: compounds 3, 2, 1 and 4 (each within the scatter of the next, the first and the last beyond it).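

Moving the nitro within the same atoms, from 3-nitrophenyl to 4-nitrophenyl on the aromatic nitrogen of the triazole-free wording aside, gives a 2.2-fold higher number from compound 3 to compound 4 (0.35 log units; beyond the scatter) in this assay, and this is the first measured step that changes where a group sits rather than whether it is there. It shows that the placement of the nitro matters in this assay, if only modestly: the 4-nitrophenyl compound does not separate from the compound carrying hydrogen, with a 1.1-fold higher number from compound 1 to compound 4 (0.04 log units; within the scatter) as the step between them, and nitro in place of acetamido gives a 1.1-fold higher number from compound 2 to compound 4 (0.06 log units; within the scatter) as its step. Among these compounds, then, the modest gain from adding a nitro belongs to the 3-nitrophenyl compound alone and does not hold for the nitro as such, with compound 4 going against any general reading.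

The compounds shown leave open whether an amine or a carboxylic acid in place of the nitro would respond to the same move from one placement to the other, or whether the effect is confined to the nitro. Nothing available accounts for the difference between the two placements.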